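The source may report more compounds than this note shows. Statements on the series, on what has been measured and on what is new or still open speak of the compounds shown alone.

Compound 3, `O=C(/C=C\Nc1ccc2cc[nH]c2c1)c1nc(-c2ccc(C(F)(F)F)cc2)n2ccccc12`, carries a 1H-indol-6-yl group on the amine nitrogen and a trifluoromethylphenyl group on the shared core. In a functional assay on B16-F10 cells (Mus musculus) for cytotoxicity, read by MTT assay, with a stated time of 48 h (on this read-out lower numbers stand for stronger inhibition and higher numbers for weaker inhibition), compound 3 gives only a limit, > 30000 nM, and not a number. Compound 2, `COc1ccc(N/C=C\C(=O)c2nc(-c3ccc(C(F)(F)F)cc3)n3ccccc23)cc1OC`, also reaches only a limit in this assay, > 30000 nM. For the measured compounds named here, compound 1, `COc1ccc(-c2nc(C(=O)/C=C\Nc3ccc4[nH]ccc4c3)c3ccccn23)cc1`, is the one measured value that is a number: in this assay compound 1 gives 5120 nM. So compound 3 stands where most of the measured values sit, at the limit of > 30000 nM in this assay, at which 2 of the 3 values shown sit.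

Compound 4, `O=C(/C=C\Nc1ccc2[nH]ccc2c1)c1nc(-c2ccc(C(F)(F)F)cc2)n2ccccc12`, is the next step: 1H-indol-5-yl in place of 1H-indol-6-yl on an amine nitrogen. Going by the values given here, the one measured single-site step, a step that the two limits leave unreadable from compound 2 to compound 3, is unreadable in size. The only indication that a 1H-indol-5-yl group can pair with a readable number comes from compound 1, whose 5120 nM was obtained with a different group on the core. The expected step is therefore uncertain, and the estimate for an at least 1.3-fold lower number from compound 3 to compound 4 (0.13 log units; that floor lies within the scatter) leans toward a modest gain at best. Compound 4 is expected to give about 22000 nM, between 6000 nM and 60000 nM.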

Compound 4, half-maximal inhibitory concentration: 18200 nM
The estimate for compound 4 lay 1.2-fold (0.08 log units) above the measured number; measured number inside the range.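

On the amine nitrogen, 1H-indol-5-yl gives compound 4 a readable number even with trifluoromethyl on the aromatic carbon, whereas compound 2 and compound 3 each stay at a limit of the assay: the limit of > 30000 nM in this assay, at which 2 of the 4 values shown sit.

In this assay, those limits allow only floors for the size of the change, an at least 1.6-fold lower number from compound 3 to compound 4 (0.21 log units; that floor lies within the scatter) and an at least 1.6-fold lower number from compound 2 to compound 4 (0.21 log units; that floor lies within the scatter). With 1H-indol-5-yl held constant, the first fully readable step appears, with trifluoromethyl in place of methoxy: a 3.6-fold higher number from compound 1 to compound 4 (0.55 log units; beyond the scatter).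

Going by these compounds, the true size of the change from 1H-indol-6-yl to 1H-indol-5-yl stays open, as does whether 1H-indol-6-yl would give a readable number alongside methoxy. Also open, on these data alone, is how a fluorine atom or an amine on that aromatic carbon would compare with methoxy and trifluoromethyl.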